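Swapping tert-butyl for a difluorobenzyl on the imidazole

The compounds below may be only part of what the source reports. "The series", "measured", "known", "first", "only" and "open" are said of these compounds alone.

Three compounds share one core and differ only in the group on the five-membered ring. In an in vitro functional assay on cells for agonist activity at Bombesin receptor subtype-3 (Homo sapiens), read by luminescence and calcium flux (a higher number here means that more compound is needed for the effect, a lower number that less compound is needed), compound 1 `N#Cc1ccccc1Cc1cnc(CCc2ccc(-c3ccccc3C(=O)O)cc2)[nH]1` gives 5480 nM, compound 2 `COc1ccccc1Cc1cnc(CCc2ccc(-c3ccccc3C(=O)O)cc2)[nH]1` gives 1720 nM and compound 3 `CC(C)(C)c1cnc(CCc2ccc(-c3ccccc3C(=O)O)cc2)[nH]1` gives 4330 nM, which is the second highest of the three numbers. Compound 4 `O=C(O)c1ccccc1-c1ccc(CCc2ncc(Cc3cccc(F)c3F)[nH]2)cc1` carries 2,3-difluorobenzyl in place of tert-butyl on an aromatic carbon. Among the measured compounds shown here, two measured steps bear on this: a 1.3-fold lower number from compound 1 to compound 3 (0.10 log units; within the scatter) and a 2.5-fold higher number from compound 2 to compound 3 (0.40 log units; beyond the scatter), so the benzyl groups seen so far gave either no clear change or a modest lower number against tert-butyl. A similar modest shift is therefore expected, a 1.7-fold lower number from compound 3 to compound 4 (0.24 log units; within the scatter). Compound 4 is estimated at 2500 nM, in the range 900 nM to 7000 nM in this assay.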

Compound 4, half-maximal effective concentration: 87 nM
Compound 4: middle estimate off by 29-fold (1.46 log units), on the high side; the whole stated range lies above it.
By their numbers in this assay, from the lowest: compound 4; then compound 2; then compounds 3 and 1 (each within the scatter of the next).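

In this assay, among the compounds shown here, this position turns out to be far more sensitive than the earlier compounds suggested, with a 50-fold lower number from compound 3 to compound 4 (1.70 log units; beyond the scatter) as the result of this change. A benzyl link alone does not account for it, as the groups on that benzyl ring matter: the 2,3-difluorobenzyl group gives a 20-fold lower number from compound 2 to compound 4 (1.30 log units; beyond the scatter) and a 63-fold lower number from compound 1 to compound 4 (1.80 log units; beyond the scatter) against the 2-methoxybenzyl and 2-cyanobenzyl groups. Nothing available here gives a reason for this drop. Still open, going by these compounds, is whether one fluorine alone would do the same, as in 2-fluorobenzyl or 3-fluorobenzyl, and where plain benzyl would fall.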